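Swapping allyloxy for benzyl on an amide tested for cytotoxicity

The compounds below may be only part of what the source reports. "The series", "measured", "known", "first", "only" and "open" are said of these compounds alone.

Three compounds share one core and were tested in an ADME assay on PC-3 cells (Homo sapiens) for cytotoxicity, read by WST assay, tested at 100 uM; a lower number here means less inhibition, a higher number more inhibition at the concentration tested (going by the name of the read-out). Compound 1 `O=C(Nc1ccc(Cl)cn1)C1CCCN(C(=O)c2cc(C(F)(F)F)cc(C(F)(F)F)c2)C1` gives 0% in this assay. Compound 2 `Cc1cccc(C(=O)N2CCCC(C(=O)Nc3ccc(Cl)cc3)C2)c1` gives 0% in this assay. Compound 3 `C=CCOc1cccc(NC(=O)C2CCCN(C(=O)c3cc(C(F)(F)F)cc(C(F)(F)F)c3)C2)c1` gives 0% in this assay, so compound 3 stands level with compounds 1 and 2 at the digits shown, and nothing separates the three beyond the scatter of the measurement.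

For the measured compounds named here, only one measured step bears directly on the new compound: the change of no change at the digits printed from compound 1 to compound 3 (within the scatter), where 3-(allyloxy)phenyl took the place of 5-chloropyridin-2-yl on an amide-type nitrogen, moved the read-out not at all.

Compound 4 `O=C(Nc1cccc(Cc2ccccc2)c1)C1CCCN(C(=O)c2cc(C(F)(F)F)cc(C(F)(F)F)c2)C1` keeps the core of compound 3 and differs from it at one place: benzyl in place of allyloxy on an aromatic carbon. Going by the values given here, no measured pair shows what a benzyl group does in this assay, so the expectation rests on the flat behaviour of compounds 1, 2 and 3 alone.

Because compound 3 sits at 0% and the earlier step gave no movement, compound 4 is expected to stay at the same level of the read-out. The step from compound 3 to compound 4 is therefore estimated as no change at the digits printed from compound 3 to compound 4 (within the scatter). Compound 4 is expected to give about 0%, within a range of -10% to 12%.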

Compound 4, a percentage reported as inhibition, at one concentration (the size of the read-out at that concentration, not a potency): 0%
For compound 4 middle estimate and measured number coincide at the digits printed; the measured number falls inside the stated range.
By their numbers in this assay, from the lowest: compounds 1, 2, 3 and 4 (each within the scatter of the next).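

In this assay, benzyl in place of allyloxy on an aromatic carbon, meta to a large group, gives no change at the digits printed from compound 3 to compound 4 (within the scatter). The earlier step replaced the whole group on the amide-type nitrogen, whereas this one alters only the substituent on that aromatic ring: 7 heavy atoms and a six-membered aromatic ring of carbon only enter, while 4 heavy atoms, a hydrogen-bond acceptor and a double bond outside aromatic rings leave, and the read-out still shows no separation. So, for this one pair, a larger all-carbon aromatic group and a smaller oxygen-linked chain cannot be told apart at this position, and no measurement shown accounts for that sameness.

With all four compounds level, the compounds shown do not reveal whether any group at this position can produce a reading that stands clear of the others. From the compounds shown here alone, an amine, a carboxylic acid or a longer chain on the same aromatic carbon remains open, as does whether such a group would behave differently from benzyl and allyloxy in this assay.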